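The compounds below may be only part of what the source reports. "The series", "measured", "known", "first", "only" and "open" are said of these compounds alone.

Compound 1, `CCCCCCCCCCCCCCCCCCOCC(CC[S+](C)[O-])NC(C)=O`, gives 60000 nM.
Compound 2, `CCCCCCCCCCCCCCCCCCOCC(COCC(F)(F)F)NC(C)=O`, gives 100000 nM.
Compound 3, `CCCCCCCCCCCCCCCCCCOCC(CCCC)NC(C)=O`, gives 60000 nM.

All three were tested in an assay for inhibition of putative inactive group IIC secretory phospholipase A2 (Homo sapiens); on this read-out lower numbers stand for stronger inhibition and higher numbers for weaker inhibition. Compound 3 stands level with compound 1, the two together giving the lowest numbers of the three, and its step to compound 2 is small: a 1.7-fold lower number from compound 2 to compound 3 (0.22 log units; within the scatter).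

Compound 4, `CCCCCCCCCCCCCCCCCCOCC(CCC(O)CO)NC(C)=O`, differs from compound 3 in one place: 1,2-dihydroxyethyl in place of ethyl on a saturated chain carbon, three bonds along the chain from an amide-type nitrogen. The measured steps that touch this part of the molecule are no change at the digits printed from compound 1 to compound 3 (within the scatter) and a 1.7-fold lower number from compound 2 to compound 3 (0.22 log units; within the scatter), and a third, a 1.7-fold higher number from compound 1 to compound 2 (0.22 log units; within the scatter), also changes the group hanging from the chain near the amide-type nitrogen. Each of these exchanges, whether a sulfur-bearing group, a trifluoroethoxy group or a plain propyl, left this assay within the scatter of repeated measurement. Among the measured compounds shown here, on that record the group at this position appears to matter little among the compounds measured so far, so no step beyond the scatter is expected in this assay for the exchange of ethyl for 1,2-dihydroxyethyl.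

Compound 4 is therefore estimated at 60000 nM, with a range from 25000 nM to 150000 nM. The expected step from compound 3 is no change at the digits printed from compound 3 to compound 4 (within the scatter).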

Compound 4, half-maximal inhibitory concentration: 8900 nM
For compound 4 the middle estimate is 6.7-fold (0.83 log units) above the measured one; measured number below the stated range.
By their numbers in this assay, from the lowest: compound 4; then compounds 1, 3 and 2 (each within the scatter of the next).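

In this assay, the position on the saturated chain carbon, three bonds along the chain from an amide-type nitrogen, no longer looks indifferent: 1,2-dihydroxyethyl in place of ethyl gives a 6.7-fold lower number from compound 3 to compound 4 (0.83 log units; beyond the scatter) and so separates this group from the others. The other two exchanges that lead to this group point the same way, with a 6.7-fold lower number from compound 1 to compound 4 (0.83 log units; beyond the scatter) and an 11-fold lower number from compound 2 to compound 4 (1.05 log units; beyond the scatter), while every step among compounds 1, 2 and 3 stays within the scatter. The group that enters carries 2 hydrogen-bond donors and 2 hydrogen-bond acceptors where ethyl carries none, but no separate measurement ties the stronger inhibition to these or to any other feature of the group.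

As far as these compounds go, it remains open whether both hydroxyl groups are needed, or whether a 2-hydroxyethyl group, with a single hydroxyl, would give a step of similar size. From the compounds shown here alone, how an amine or a carboxylic acid at this place would compare is equally open, as is whether the step would persist with a shorter version of the long chain in the shared core.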